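Halogen swap on the terminal aryl urea of compound 1

The source may hold more compounds than are shown below. What is called first, only, known or untested is meant among the compounds shown, and "the series" means these compounds.

Measured so far:
compound 1 `COc1cc(NC(C)CCCNC(=O)Nc2cccc(F)c2)c2ncccc2c1`: 23000 nM
compound 2 `COc1cc(NC(C)CCCNC(=O)NNC(=O)Nc2cccc(F)c2)c2ncccc2c1`: >= 250000 nM

Going by the values given here, in a functional assay on MOLT-4 cells (Homo sapiens) for inhibition, read by MTT assay, with a stated time of 72 h (on this read-out higher numbers stand for weaker inhibition and lower numbers for stronger inhibition), compound 1 gives 23000 nM, the only real number among the two values shown. For compound 2 `COc1cc(NC(C)CCCNC(=O)NNC(=O)Nc2cccc(F)c2)c2ncccc2c1` the result is a limit of the assay, >= 250000 nM, not a number (the limit of >= 250000 nM in this assay, at which 1 of the 2 values shown sits). Among the compounds with values here, the one measured step, an at least 10-fold higher number from compound 1 to compound 2 (1.03 log units; beyond the scatter), is large, but it concerns a different change: ((3-fluorophenyl)carbamoyl)amino in place of 3-fluorophenyl on an amide-type nitrogen. Compound 3 `COc1cc(NC(C)CCCNC(=O)Nc2ccc(Cl)cc2)c2ncccc2c1` instead keeps the urea intact and differs from compound 1 only in the aryl group: 4-chlorophenyl in place of 3-fluorophenyl on an amide-type nitrogen. Within the data shown here, no measured step in this set touches a change of that kind, so nothing here argues for a shift beyond the scatter in either direction. The expectation for compound 3 is therefore a value close to that of compound 1, a 1.2-fold lower number from compound 1 to compound 3 (0.06 log units; within the scatter), with the estimate in this assay for compound 3 at 20000 nM, ranging from 7000 nM to 60000 nM.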

Compound 3, half-maximal inhibitory concentration: 24000 nM
Compound 3: the middle estimate sits 1.2-fold (0.08 log units) below what was measured, within the range that was stated.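

In this assay, putting 4-chlorophenyl in place of 3-fluorophenyl on the amide-type nitrogen gives a 1.0-fold higher number from compound 1 to compound 3 (0.02 log units; within the scatter), so these two halogen-bearing phenyl groups cannot be told apart at this position on this read-out. Within this small set, the choice between them matters far less than the change at the same nitrogen that leads to compound 2, where the ((3-fluorophenyl)carbamoyl)amino group replaces the aryl group and the urea no longer stands alone. The second step, an at least 10-fold lower number from compound 2 to compound 3 (1.01 log units; beyond the scatter), rests at one end on a limit and not a number, the value of compound 2: the limit of >= 250000 nM in this assay, at which 1 of the 3 values shown sits.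

The halogen and its place on the ring changed together between compound 1 and compound 3, so the compounds shown do not separate the two, and 3-chlorophenyl or 4-fluorophenyl would be needed to read each alone. They also leave open whether an unsubstituted phenyl, a phenyl carrying a carboxylic acid or an amine, or a pyridine at this nitrogen would stay level with compound 1 and compound 3 or move away from them.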